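This account rests on a few compounds, and the source may have more. Where it says the series, first, only, none or still open, it means among the compounds named here.

Measured so far in a physicochemical assay for solubility, read by LC-MS, in phosphate buffer, with a stated time of 24 h, at pH 7.4; a higher number here means a more soluble compound, a lower number a less soluble compound

Compound 1 `C[C@@H]1CC(=O)N(c2cnc(NCc3c(F)ccc4c3CCO4)n3cnnc23)C1` gives 130000 nM
Compound 2 `CC(=O)N1CCC(c2cnc(NCc3c(F)ccc4c3CCO4)c3cn[nH]c(=O)c23)CC1` gives < 2000 nM (a limit)
Compound 3 `CN(c1ccccc1)c1cnc(NCc2c(F)ccc3c2CCO3)n2cnnc12` gives < 2000 nM (a limit)

Compound 2 has no exact number in this assay, only a limit. It stands at the limit of < 2000 nM in this assay, at which 2 of the 3 values shown sit.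

The next step leads to compound 4 `CNC(=O)c1ccc(-c2cnc(NCc3c(F)ccc4c3CCO4)c3cn[nH]c(=O)c23)c(C)n1`, which carries 2-methyl-6-(methylcarbamoyl)pyridin-3-yl in place of 1-acetylpiperidin-4-yl on an aromatic carbon of the shared core. The change counts as follows: 2-methyl-6-(methylcarbamoyl)pyridin-3-yl in place of 1-acetylpiperidin-4-yl on an aromatic carbon.

Going by the values given here, only one measured step offers a comparison: an at least 65-fold lower number from compound 1 to compound 3 (1.81 log units; beyond the scatter). It is large, and there too a group holding an aromatic ring took the place of a non-aromatic ring. It is only a loose guide, as it was measured on the core of compound 1, which differs from the core of compound 2, and it ends at a limit.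

Given an at least 65-fold lower number from compound 1 to compound 3 (1.81 log units; beyond the scatter), the swap is not expected to lift compound 4 far from where compound 2 stands. The expected change is small and has no firm direction: a step that the limit leaves unreadable from compound 2 to compound 4. For compound 4 the estimated solubility is 1200 nM, with an expected range from 250 nM to 6000 nM.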

Compound 4, solubility: 19000 nM
Compound 4: the middle estimate sits 16-fold (1.20 log units) below what was measured; measured number above the stated range.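

In this assay, placing 2-methyl-6-(methylcarbamoyl)pyridin-3-yl in place of 1-acetylpiperidin-4-yl gives an at least 9.5-fold higher number from compound 2 to compound 4 (0.97 log units; beyond the scatter), so the read-out does respond to what sits at this aromatic carbon of the shared core. An aromatic ring in the entering group does not settle the direction across the compounds shown, as the other readable step runs the opposite way and goes against any such pattern: an at least 65-fold lower number from compound 1 to compound 3 (1.81 log units; beyond the scatter), though on a different core. The true size of the rise from compound 2 is not known, and the printed step is only a minimum because compound 2 has a limit and not an exact number: the limit of < 2000 nM in this assay, at which 2 of the 4 values shown sit.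

The swap changes several things at once, including the ring type, the added methyl and the methylcarbamoyl with its amide hydrogen, so the compounds shown cannot assign the rise to any one of these parts. As far as these compounds go, it remains open whether a plain pyridin-3-yl group, or a pyridine carrying a carboxylic acid or an amine in place of the methylcarbamoyl, would give a similar number at this position.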